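This account rests on a few compounds, and the source may have more. Where it says the series, first, only, none or still open, it means among the compounds named here.

Compound 1 `Nc1cc(N)c2nc(-c3ccccc3)c(NCc3ccc(Cl)c(Cl)c3)nc2c1` has the lowest number of the two compounds measured in a functional assay on UACC-257 cells (Homo sapiens) for inhibition, read by sulforhodamine B assay, with a stated time of 48 h (a higher number here means a weaker inhibitor of growth, a lower number a stronger inhibitor of growth), where compound 1 gives 4570 nM. Going by the values given here, the only other measured compound, compound 2 `CCOC(=O)[C@H](CCC(=O)O)NC(=O)c1ccc(CNc2nc3cc(N)cc(N)c3nc2-c2ccccc2)cc1`, gives 19500 nM in this assay, a gap beyond the usual scatter. Compound 3 `COc1ccc(CNc2nc3cc(N)cc(N)c3nc2-c2ccccc2)cc1` differs from compound 1 in one place: 4-methoxyphenyl in place of 3,4-dichlorophenyl on a saturated chain carbon bound to a nitrogen on an aromatic ring. Among the compounds with values here, no measured pair shows a change of this kind here, so only a small step is expected, toward a higher number, and it may well sit within the scatter. The growth-inhibiting concentration of compound 3 is estimated at 8000 nM, most likely between 3000 nM and 22000 nM. This expectation amounts to a step of a 1.8-fold higher number from compound 1 to compound 3 (0.24 log units; within the scatter).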

Compound 3, concentration for 50% growth inhibition: 16200 nM
Compound 3: middle estimate off by 2.0-fold (0.31 log units), on the low side, and the stated range covers the measured number.
By their numbers in this assay, from the lowest: compound 1; then compounds 3 and 2 (each within the scatter of the next).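

In this assay, putting 4-methoxyphenyl in place of 3,4-dichlorophenyl on a saturated chain carbon bound to a nitrogen on an aromatic ring gives a 3.5-fold higher number from compound 1 to compound 3 (0.55 log units; beyond the scatter). This single change to the core of compound 1 shows that the group at this position affects growth inhibition, and that 3,4-dichlorophenyl gives the lower number of this pair. Nothing available explains this step. Still open, on these data alone, is whether losing the two chlorines or gaining the methoxy group accounts for the step. As far as these compounds go, how 4-chlorophenyl or 4-aminophenyl would compare at this position also remains open.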